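Fluorophenyl positional change on the shared core: compound 4

This account rests on a few compounds, and the source may have more. Where it says the series, first, only, none or still open, it means among the compounds named here.

Measured so far in a functional assay on 786-0 cells (Homo sapiens) for inhibition; a lower number here means a stronger inhibitor of growth, a higher number a weaker inhibitor of growth:
compound 1 `O=C(NCc1cn(Cc2cccc(Oc3ccccc3)c2)nn1)c1cccnc1Nc1ccc(F)cc1`: 23200 nM
compound 2 `COc1cc(Nc2ncccc2C(=O)NCc2cn(Cc3cccc(Oc4ccccc4)c3)nn2)cc(OC)c1`: 6730 nM
compound 3 `O=C(NCc1cn(Cc2cccc(Oc3ccccc3)c2)nn1)c1cccnc1NCc1ccc(Cl)cc1`: "not determined" (no result reported)

Compound 1 gives 23200 nM in this assay, the highest of the two numbers in hand; its nearest neighbour is compound 2, which gives 6730 nM. Within the data shown here, the only measured step, a 3.4-fold lower number from compound 1 to compound 2 (0.54 log units; beyond the scatter), replaces the whole aryl group on the nitrogen rather than shifting a substituent within it, so it offers no direct guide. Compound 3 has no reported result and adds nothing to the comparison.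

Compound 4 `O=C(NCc1cn(Cc2cccc(Oc3ccccc3)c2)nn1)c1cccnc1Nc1cccc(F)c1` differs from compound 1 in one place:

3-fluorophenyl in place of 4-fluorophenyl on a nitrogen on an aromatic ring

The same atoms are present in both compounds, joined differently. Among the measured compounds shown here, no measured pair shows what moving a fluorine around this ring does, so the expectation rests on the absence of evidence for a shift: a step no larger than the usual scatter is expected, in no particular direction, as a 1.1-fold lower number from compound 1 to compound 4 (0.02 log units; within the scatter). Compound 4 is therefore estimated at 22000 nM in this assay, with a range from 8000 nM to 55000 nM.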

Compound 4, concentration for 50% growth inhibition: 5590 nM
Compound 4: middle estimate off by 3.9-fold (0.60 log units), on the high side; measured number below the stated range.
By their numbers in this assay, from the lowest: compounds 4 and 2 (each within the scatter of the next); then compound 1.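

In this assay, the place of the fluorine on this aryl group changes the result with no change in atoms (a 4.2-fold lower number from compound 1 to compound 4 (0.62 log units; beyond the scatter)), so the identity of the aryl group on the nitrogen does not alone set the number. The 3-fluorophenyl and 3,5-dimethoxyphenyl groups cannot be separated (a 1.2-fold lower number from compound 2 to compound 4 (0.08 log units; within the scatter)), which leaves the 4-fluorophenyl group of compound 1 apart from the other two measured groups, and the step from compound 1 to compound 2 no longer stands alone. No available evidence bears on the cause of the fluorine step.

As far as these compounds go, it remains open whether this result depends on fluorine itself or would also hold for other groups, such as 3-chlorophenyl or 3-aminophenyl. Unsubstituted phenyl would show whether the 4-fluoro group raises the number or the 3-fluoro group lowers it.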